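Side-chain variation on a shared core in the tail flick test

The source may hold more compounds than are shown below. What is called first, only, known or untested is meant among the compounds shown, and "the series" means these compounds.

Two compounds of the series carry measured numbers in a functional assay on the whole organism (Tail, strain ICR) with Mus musculus as the target, in the tail flick test, with a stated time of 120 min, at a dose of 25 umol/kg by the oral route; on this read-out lower numbers stand for a weaker effect and higher numbers for a stronger effect at the one dose given. Compound 1, `CC[C@H](C)[C@H](NC(=O)CN(c1nc(Cl)nc2[nH]cnc12)C1CC1)C(=O)O`, gives 21.4% in this assay. Compound 2, `NCCCC[C@H](NC(=O)CN(c1nc(Cl)nc2[nH]cnc12)C1CC1)C(=O)OCc1ccccc1`, gives 16.8% in this assay. Compound 1 holds the higher of the two numbers, but its gap to compound 2 lies within the usual scatter, so the two readings cannot be told apart. Going by the values given here, no pair among the measured compounds differs in one place only, so no single-change step has yet been observed.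

Compound 3, `O=C(O)CC[C@H](NC(=O)CN(c1nc(Cl)nc2[nH]cnc12)C1CC1)C(=O)O`, is still to be measured in this assay. Against compound 1 the change is 2-carboxyethyl in place of sec-butyl on a saturated chain carbon bound to an amide-type nitrogen and a carbonyl carbon. The measured pair offers no guidance on a change of this kind, and nothing in the two readings points to a direction. Among the compounds with values here, a step within the scatter is therefore expected, a number 4.4 percentage points lower from compound 1 to compound 3 (within the scatter), with a wide range because no comparable step has been measured. Compound 3 is expected to give about 17% in this assay, with the estimate spanning 4% to 32%.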

Compound 3, a percentage reported as activity, at one dose (the size of the read-out at that dose, not a potency): 30.1%
Compound 3: middle estimate off by 13.1 percentage points, on the low side, within the range that was stated.
By their numbers in this assay, from the lowest: compounds 2, 1 and 3 (each within the scatter of the next, the first and the last beyond it).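

Going by these compounds alone, this is the first single-change step: in this assay, 2-carboxyethyl in place of sec-butyl on a saturated chain carbon bound to an amide-type nitrogen and a carbonyl carbon gives a number 8.7 percentage points higher from compound 1 to compound 3 (within the scatter). At this position, then, a side chain with no hydrogen-bond donors or acceptors and one with 1 hydrogen-bond donor and 1 hydrogen-bond acceptor cannot be told apart at the one dose and time tested, so this change has not been shown to alter the read-out in either direction. No measurement is available that bears on why the step has this size.

On these data alone, it remains open whether any group at this position would move the read-out beyond the scatter from compound 1, for example carboxymethyl, 3-carboxypropyl with its longer chain, the neutral amide 2-carbamoylethyl, or the amine 2-aminoethyl. A single step also cannot show whether the size of this change would hold at other doses or times, so no trend along the side chain can yet be drawn.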